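Methyl for fluoro on a hydrazone thiazole series

This account rests on a few compounds, and the source may have more. Where it says the series, first, only, none or still open, it means among the compounds named here.

Of the compounds shown here, three have been measured in a functional assay, read by spectrophotometry, with a stated time of 15 min, tested at 80 ug/mL; a higher number here means a stronger effect of the compound at the concentration tested, a lower number a weaker effect. Compound 1 `Fc1ccc(-c2csc(N/N=C/c3ccc(Cl)cc3Cl)n2)cc1` gives 94%, and compound 2 `Cc1ccc(-c2csc(N/N=C/c3ccc(Cl)cc3Cl)n2)cc1`, which carries methyl in place of fluoro on an aromatic carbon, gives 84.2%. The step of a number 9.8 percentage points lower from compound 1 to compound 2 (within the scatter) shows that this change left the read-out within the usual scatter. Compound 3 `Fc1ccc(-c2csc(N/N=C/c3cccs3)n2)cc1`, built on a second core, gives 91.9% in this assay, a number that lies within the scatter of compound 1 and of compound 2 alike. The difference between the two cores is not broken down here.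

Compound 4 `Cc1ccc(-c2csc(N/N=C/c3cccs3)n2)cc1` has not yet been measured. It differs from compound 3 by methyl in place of fluoro on an aromatic carbon, the same change that separates compound 1 from compound 2, made on the same place of the ring and in the same words. Going by the values given here, the only guide to the size of its effect is the step from compound 1 to compound 2, which was small and within the scatter. Among the compounds with values here, on that basis the step from compound 3 to compound 4 in this assay is expected to be about a number 8.9 percentage points lower from compound 3 to compound 4 (within the scatter), resting on the single measured pair. Compound 4 is therefore estimated to give 83% in this assay, with a plausible range from 72% to 93%.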

Compound 4, a percentage reported as inhibition, at one concentration (the size of the read-out at that concentration, not a potency): 88.4%
Beside the measured number, compound 4's estimate is 5.4 percentage points below it; low and high end bracket the measured number.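

In this assay, methyl in place of fluoro on the core of compound 3 gives a number 3.5 percentage points lower from compound 3 to compound 4 (within the scatter), and the earlier step on the core of compound 1 is also printed as within the scatter. Set side by side, the two steps do not differ, so in this small set the change carries from one core to the other without any visible shift in its size: the same change on two cores in this assay, a number 9.8 percentage points lower (within the scatter) from compound 1 to compound 2 and a number 3.5 percentage points lower (within the scatter) from compound 3 to compound 4, 6.3 percentage points apart, within the scatter of two such steps

Going by these compounds alone, this shows only that the swap of fluoro for methyl, on an aromatic carbon para to a large group, leaves the read-out inside the usual scatter on both cores; it does not show that the change has a real effect of a fixed size, since neither step can be told from repeated measurement, and one pair on each of two cores is no rule for the series or for other cores, and a reading at a single concentration says nothing about potency.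

The compounds shown leave open whether the same place on the ring tolerates groups of another kind, such as an amine, a carboxylic acid or a longer chain. They also leave open whether steps from such groups would carry between the two cores as closely as this one does.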